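The source may hold more compounds than are shown below. What is called first, only, known or untested is meant among the compounds shown, and "the series" means these compounds.

Of the compounds shown here, two built on one shared core have so far been tested in a functional assay on CCRF-CEM cells (Homo sapiens) for antiproliferative activity, read by MTT assay, with a stated time of 24 h, tested at 100 uM; on this read-out lower numbers stand for a stronger effect and higher numbers for a weaker effect at the one concentration tested. Compound 1 `OC(CCn1nc2c(Br)c(Br)c(Br)c(Br)c2n1)c1cccc(Cl)c1` gives 0%, while compound 2 `OC(CCn1nc2c(Br)c(Br)c(Br)c(Br)c2n1)c1ccccc1` gives 21%. Among the compounds with values here, compound 2 therefore holds the higher of the two numbers, which here means the weaker effect, and the only measured comparison is the step of a number 21 percentage points higher from compound 1 to compound 2 (beyond the scatter). Compound 3 `OC(CCn1nc2c(Br)c(Br)c(Br)c(Br)c2n1)c1ccc(Cl)cc1` has not yet been measured; it differs from compound 2 by chloro in place of hydrogen on an aromatic carbon. Within the data shown here, the one known step runs the other way, taking a chloro off the ring and raising the number, so putting a chloro back onto the ring is expected to lower the number by a comparable amount. The step expected is a number 16 percentage points lower from compound 2 to compound 3 (beyond the scatter), a drop toward the floor of the read-out. Compound 3 is estimated at 5%, with a likely range from 0% to 25%.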

Compound 3, a percentage reported as activity, at one concentration (the size of the read-out at that concentration, not a potency): 0%
Compound 3: the middle estimate sits 5 percentage points above what was measured; the range from low to high includes it.
By their numbers in this assay, from the lowest: compounds 1 and 3 (each within the scatter of the next); then compound 2.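

Swapping phenyl for 4-chlorophenyl gives a number 21 percentage points lower from compound 2 to compound 3 (beyond the scatter) in this assay, so the lower number that came with a chloro on compound 1 does not depend on a single ring position. Moving the chloro gives no change at the digits printed from compound 1 to compound 3 (within the scatter), which means the 3-chlorophenyl and 4-chlorophenyl groups cannot be told apart in this assay. Both compounds sit at the bottom of the read-out at the one concentration tested, so any real difference between them would stay hidden there.

From the compounds shown here alone, whether a fluoro, a methoxy or an amine at the same place on the ring would also bring the number down remains open, as does how the compounds would rank at lower concentrations. No evidence is available to explain why adding the chloro goes with this change.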